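Chloro in Place of Hydrogen on the Shared Core

The source may report more compounds than this note shows. Statements on the series, on what has been measured and on what is new or still open speak of the compounds shown alone.

Measured compounds:
compound 1, `Cc1cc(C)cc(NC(=O)COc2cc(C)nc3ccccc23)c1`: 5.39
compound 2, `CSc1ccc2nc(C)cc(OCC(=O)Nc3cc(C)cc(C)c3)c2c1`: 6.42
compound 3, `Cc1cc(C)cc(NC(=O)COc2cc(C)nc3ccc(F)cc23)c1`: 5.79

Of the compounds shown here, three built on one shared core have been measured in a physicochemical assay for lipophilicity, read by HPLC, in phosphate buffer, measured as chromatographic lipophilicity, at pH 7.4; a lower number here means a more polar compound, a higher number a more lipophilic compound. Compound 1, carrying hydrogen at the position of interest, stands lowest of the three. Its nearest neighbour is compound 3, reached by a step of a number 0.40 log units higher from compound 1 to compound 3 (beyond the scatter), a modest rise. The furthest is compound 2, reached by a number 1.03 log units higher from compound 1 to compound 2 (beyond the scatter), a large rise.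

Compound 4, `Cc1cc(C)cc(NC(=O)COc2cc(C)nc3ccc(Cl)cc23)c1`, is the next member. Compared with compound 1 the change is chloro in place of hydrogen on an aromatic carbon, at the same place where compound 3 carries fluoro and compound 2 carries methylsulfanyl. Both earlier steps therefore bear on it: the modest rise to compound 3 and the large rise to compound 2. A rise in this assay beyond the scatter is expected, and its size is estimated to fall between those two steps. Compound 4 is expected to give 6.1, within a range of 5.85 to 6.35. The expected step is a number 0.71 log units higher from compound 1 to compound 4 (beyond the scatter).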

Compound 4, distribution coefficient: 6.38
The estimate for compound 4 lay 0.28 log units below the measured number; the measured number lies above the stated range.
By their numbers in this assay, from the lowest: compound 1; then compound 3; then compounds 4 and 2 (each within the scatter of the next).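

Chloro in place of hydrogen at this position gives a number 0.99 log units higher from compound 1 to compound 4 (beyond the scatter) in this assay, so all three replacements shown for hydrogen here raise the number, with no compound going against this. The new result also separates the replacements: chloro in place of fluoro gives a number 0.59 log units higher from compound 3 to compound 4 (beyond the scatter), while chloro in place of methylsulfanyl gives a number 0.04 log units lower from compound 2 to compound 4 (within the scatter), so compound 4 and compound 2 cannot be told apart in this assay. The compounds shown offer no independent measurement that explains the sizes of these steps.

As far as these compounds go, it remains open whether an amine or a carboxylic acid at this position would also raise the number. Also open, from the compounds shown here alone, is whether chloro would give a similar step at another place on the shared core.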